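The source may hold more compounds than are shown below. What is called first, only, known or untested is meant among the compounds shown, and "the series" means these compounds.

Measured compounds:
- compound 1, `C=CCn1c(=O)/c(=C\c2ccc(Cl)c(Cl)c2)[nH]c(=O)/c1=C\c1ccccc1`, gives "not active" (no number reported) in a functional assay on MCF7 cells (Homo sapiens) for cytotoxicity, read by CCK-8 assay, with a stated time of 72 h; on this read-out lower numbers stand for stronger inhibition and higher numbers for weaker inhibition
- compound 2, `C=CCn1c(=O)/c(=C\c2ccc(F)c(Br)c2)[nH]c(=O)/c1=C\c1ccccc1OC`, gives "not active" (no number reported) in this assay
- compound 3, `COc1ccccc1/C=c1/[nH]c(=O)/c(=C\c2nc[nH]c2C(C)(C)C)[nH]c1=O`, gives 100 nM in this assay

Compound 2 stands without a single number in this assay: it is reported only as inactive, and compound 1 is reported the same way, so neither can be ranked against the other. Only compound 3 has a measured concentration, and it carries a different core, so it offers no direct comparison with compound 2.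

Compound 4, `C=CCn1c(=O)/c(=C\c2cccc(Cl)c2Cl)[nH]c(=O)/c1=C\c1ccccc1OC`, is the next compound to be measured in this assay. Its change from compound 2 is 2,3-dichlorophenyl in place of 3-bromo-4-fluorophenyl on a double-bonded chain carbon bound to an aromatic carbon. Going by the values given here, no step between two measured compounds of this kind is available, so the size of the step cannot be taken from the data. Among the compounds with values here, what the data do show is that compound 1, which also carries a dichlorophenyl on this double-bonded chain carbon, is reported as inactive, and compound 2 itself is inactive; nothing among the measured compounds points toward a gain. The expectation is therefore that compound 4 stays weak in this assay, most likely again without a number. If a number is returned, compound 4 is estimated at 40000 nM, expected to lie between 8000 nM and 200000 nM.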

Compound 4, half-maximal inhibitory concentration: 2100 nM
Estimate against measurement, compound 4: 19-fold (1.28 log units) above; the whole stated range lies above it.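

No step can be read from compound 2 to compound 4: in this assay compound 4 gives 2100 nM, while compound 2 gives "not active" (no number reported). The compounds shown leave open how large the effect of 2,3-dichlorophenyl in place of 3-bromo-4-fluorophenyl is. No available evidence bears on this result.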